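This account rests on a few compounds, and the source may have more. Where it says the series, first, only, none or still open, it means among the compounds named here.

In an ADME assay on Vero cells (Chlorocebus sabaeus) for cytotoxicity, read by XTT assay, with a stated time of 72 h (on this read-out higher numbers stand for lower toxicity in this test and lower numbers for higher toxicity in this test), compound 1 `CC1=C(C(=O)Nc2ccc(F)cc2)C(c2ccccc2)NC(=O)N1` gives > 100000 nM, which is a limit of the assay rather than a number. Compound 2 `CC1=C(C(=O)Nc2ccccc2Cl)C(c2ccc(Br)cc2)NC(=O)N1` likewise reaches only a limit in this assay, namely > 100000 nM. Compound 3 `CC1=C(C(=O)Oc2ccccc2)C(c2ccccc2)NC(=S)N1` is entered in this assay as "non-toxic" (no number reported), with no number behind it. Compound 2 therefore stands at the limit of this assay, where one further value also sits, while the remaining entry carries no number at all. Compound 4 `CC1=C(C(=O)Nc2ccccc2Cl)C(c2cccs2)NC(=O)N1` differs from compound 2 by thiophen-2-yl in place of 4-bromophenyl on a saturated ring carbon. Within the data shown here, no step between measured compounds is known here. Because two of the three values sit at the limit of > 100000 nM in this assay, at which 2 of the 3 values shown sit, compound 4 is expected to show no step beyond the scatter in this assay, with an estimated value of 100000 nM, ranging from 40000 nM to 300000 nM, an expected step of a number no higher from compound 2 to compound 4 (the limit leaves the size open).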

Compound 4, half-maximal cytotoxic concentration: > 100000 nM
Compound 4 was reported as a limit (the forecaster's own chance of this, stated with the estimate: 75%); the middle value lies on the limit itself.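

In this assay, among these compounds, compound 4 gives > 100000 nM, which is a limit; compound 2 also sits at a limit, so no step between compound 2 and compound 4 can be read. The compounds shown leave open whether thiophen-2-yl and 4-bromophenyl differ at all here.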